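A few compounds are considered here, and "the series" means these few. Any claim that something is new, unique, unknown or untested is made for them only; others in the source may bear on it.

Measured in a functional assay on RS4-11 cells (Homo sapiens) for inhibition, read by CCK-8 assay, with a stated time of 72 h; a lower number here means a stronger inhibitor, a higher number a weaker inhibitor:
- compound 1 `CC1(C)CCC(CN2CCN(c3ccc(C(=O)NS(=O)(=O)c4ccc(NCC5CCOCC5)c([N+](=O)[O-])c4)c(Oc4cnc5[nH]ccc5c4)c3)CC2)=C(c2ccc(C(F)(F)F)cc2)C1`: 6.2 nM
- compound 2 `COc1ccc(C2=C(CN3CCN(c4ccc(C(=O)NS(=O)(=O)c5ccc(NCC6CCOCC6)c([N+](=O)[O-])c5)c(Oc5cnc6[nH]ccc6c5)c4)CC3)CCC(C)(C)C2)cc1`: 12 nM

For the measured compounds named here, compound 1 and compound 2 lie within the scatter of each other, so compound 1 does not stand apart from the only other measured compound.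

Compound 3 `CC1(C)CCC(CN2CCN(c3ccc(C(=O)NS(=O)(=O)c4ccc(OCC5CCOC5)c([N+](=O)[O-])c4)c(Oc4cnc5[nH]ccc5c4)c3)CC2)=C(c2ccc(C(F)(F)F)cc2)C1` is the next to be read against compound 1. The difference is (oxolan-3-yl)methoxy in place of ((oxan-4-yl)methyl)amino on an aromatic carbon, on an aromatic carbon ortho to a nitro group.

Going by the values given here, the one measured step, a 1.9-fold higher number from compound 1 to compound 2 (0.29 log units; within the scatter), is methoxy in place of trifluoromethyl and does not touch this place. Among the compounds with values here, it therefore offers little guidance, and no measured step shows what this exchange does. A modest rise in the number is assumed, though a result within the scatter would fit equally well. The expected change is a 2.3-fold higher number from compound 1 to compound 3 (0.35 log units; beyond the scatter). For compound 3 the estimated value in this assay is 14 nM, with an expected range of 4 nM to 50 nM.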

Compound 3, half-maximal inhibitory concentration: 47 nM
Beside the measured number, compound 3's estimate is 3.4-fold (0.53 log units) below it; measured number inside the range.
By their numbers in this assay, from the lowest: compounds 1 and 2 (each within the scatter of the next); then compound 3.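

In this assay, the position on the aromatic carbon ortho to a nitro group is sensitive to this exchange: a 7.6-fold higher number from compound 1 to compound 3 (0.88 log units; beyond the scatter) is seen on going to (oxolan-3-yl)methoxy, whereas the earlier step at the other site stayed within the scatter. The exchange changes several features at once, from a six-membered to a five-membered non-aromatic ring, from an amino to an oxygen link, and from 1 hydrogen-bond donor to 0, so this step cannot be assigned to any one of them. Nothing available explains the size of this step.

Still open, going by these compounds, is whether ring or link carries the step, a question that (oxan-4-yl)methoxy or ((oxolan-3-yl)methyl)amino at this position would separate. On these data alone, how a morpholine-bearing amine or a longer alkylamino chain would read here also remains open.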